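Working notes: pyrimidin-2-yl in place of phenyl

A few compounds are considered here, and "the series" means these few. Any claim that something is new, unique, unknown or untested is made for them only; others in the source may bear on it.

Measured so far in a physicochemical assay for lipophilicity, read by HPLC, measured as chromatographic lipophilicity, at pH 7.4; a higher number here means a more lipophilic compound, a lower number a more polar compound
- Compound 1 `O=C(C1CCN(c2ccccc2)CC1)N1N=CC[C@H]1c1ccccc1` gives 6.3
- Compound 2 `Cc1ccc(C2CC=NN2C(=O)C(C)(C)C)cc1` gives 6.4
- Compound 3 `CC(=O)N1CCC(C(=O)N2N=CCC2c2ccccc2)CC1` gives 2.5

Compound 1 sits with compound 2 at the top of this small set, the two lying within the scatter of each other. Compound 3 lies far lower, beyond the scatter of either. The next compound to be read is compound 4 `O=C(C1CCN(c2ncccn2)CC1)N1N=CC[C@H]1c1ccccc1` which carries pyrimidin-2-yl in place of phenyl on an amine nitrogen in a ring and otherwise matches compound 1.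

For the measured compounds named here, no two measured compounds differ in one place only, so the set offers no direct step for this change. The expectation therefore rests on the structural change itself, with compound 1 (at 6.3) as the starting point and compound 3 (at 2.5) as the only low reference. In this assay a fall beyond the scatter is expected, of moderate size and far smaller than the whole span of the set (estimated a number 1.30 log units lower from compound 1 to compound 4 (beyond the scatter)). The estimate for compound 4 is 5 (expected range 4.4 to 5.6).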

Compound 4, distribution coefficient: 4.7
Estimate against measurement, compound 4: 0.30 log units above; measured number inside the range.
By their numbers in this assay, from the lowest: compound 3; then compound 4; then compounds 1 and 2 (each within the scatter of the next).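

For the compounds shown here, the first direct step reads a number 1.60 log units lower from compound 1 to compound 4 (beyond the scatter) in this assay, for pyrimidin-2-yl in place of phenyl on an amine nitrogen in a ring, with the rest of the structure held constant. The number at this position therefore responds strongly to an exchange that keeps the count of 6 heavy atoms and no net charge on either side, but replaces a six-membered aromatic ring of carbon only with one that has 2 hetero atoms and 2 hydrogen-bond acceptors. Nothing measured here accounts for the size of this step.

On these data alone, this reading rests on a single matched pair, so it remains open whether pyridin-2-yl or pyrimidin-5-yl on the same ring nitrogen would give a step of similar size, or a smaller one. As far as these compounds go, it also remains open whether the same exchange of phenyl for pyrimidin-2-yl would carry over to a compound with a different group in place of the phenyl on the shared core, such as cyclohexyl or a longer chain.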